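This account rests on a few compounds, and the source may have more. Where it says the series, first, only, none or still open, it means among the compounds named here.

The measured compounds and their numbers in an assay on HEK293 cells for antagonist activity at Toll-like receptor 9 (Homo sapiens), read by spectrophotometry; a lower number here means a stronger inhibitor, a higher number a weaker inhibitor:

Compound 1 `CCN1CCN(CCCn2cnc3c(N4CCN(CC)CC4)ncnc32)CC1` gives 1190 nM.
Compound 2 `CN(C)Cc1ccc(CNc2nc(N3CCN(C4CCCC4)CC3)c3ncn(CCCN4CCCC4)c3n2)cc1` gives 7 nM.
Compound 3 `Fc1ccc(CNc2nc(N3CCN(C4CCCC4)CC3)c3ncn(CCCN4CCCC4)c3n2)cc1` gives 100 nM.

Compound 1 stands highest of the three in this assay: compound 3 gives a lower number, and compound 2 a lower number still, with both gaps beyond the scatter. Compound 4 `CCN1CCN(CCCn2cnc3c(N4CCN(CC)CC4)nc(N4CCCC4)nc32)CC1` differs from compound 1 by pyrrolidin-1-yl in place of hydrogen on an aromatic carbon. For the measured compounds named here, the only measured step, a 14-fold higher number from compound 2 to compound 3 (1.15 log units; beyond the scatter), concerns a group on a separate aromatic ring that compound 1 does not carry, so it does not bear directly on this change. Going by the values given here, compounds 2 and 3 differ from compound 1 in several places at once, so none of the measured pairs isolates the effect of adding pyrrolidin-1-yl at this carbon. He therefore expects for compound 4 a moderate lowering, a 3.0-fold lower number from compound 1 to compound 4 (0.47 log units; beyond the scatter), with wide uncertainty. His estimate for compound 4 in this assay is 400 nM, within a range from 100 nM to 1500 nM.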

Compound 4, half-maximal inhibitory concentration: 500 nM
Estimate against measurement, compound 4: 1.3-fold (0.10 log units) below; measured number inside the range.
By their numbers in this assay, from the lowest: compound 2; then compound 3; then compound 4; then compound 1.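

In this assay, for the compounds shown here, pyrrolidin-1-yl in place of hydrogen on the aromatic carbon between two ring nitrogen atoms gives a 2.4-fold lower number from compound 1 to compound 4 (0.38 log units; beyond the scatter), which is the first single-place change read at this carbon. The step is modest, but it shows that this carbon can carry a five-membered non-aromatic ring while the number goes down rather than up. Nothing measured here accounts for the step.

The compounds shown leave open whether this step belongs to pyrrolidin-1-yl in particular or would also appear with another group at this carbon, such as dimethylamino, morpholin-4-yl or a plain methyl. They also leave open whether the step would keep its size with different groups elsewhere on the core.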